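Methyl shift on the thiophene: compound 3

The compounds below may be only part of what the source reports. "The series", "measured", "known", "first", "only" and "open" are said of these compounds alone.

compound 1 `Cc1ccc(CS/C(=C/c2ccccc2F)C(=O)c2ccc(Cl)cc2)cc1` gives 10000 nM in a functional assay on DU-145 cells (Homo sapiens) for inhibition, read by trypan blue exclusion, with a stated time of 96 h; on this read-out higher numbers stand for weaker inhibition of growth and lower numbers for stronger inhibition of growth
compound 2 `Cc1ccc(CS/C(=C/c2sccc2C)C(=O)c2ccc(Cl)cc2)cc1` gives 10000 nM in this assay

Level with compound 1, compound 2 stands at 10000 nM in this assay on the numbers so far. Compound 3 `Cc1ccc(CS/C(=C/c2ccc(C)s2)C(=O)c2ccc(Cl)cc2)cc1` carries 5-methylthiophen-2-yl in place of 3-methylthiophen-2-yl on a double-bonded chain carbon bound to a double-bonded chain carbon with the same atoms joined differently. Among the compounds with values here, one measured step bears on this, no change at the digits printed from compound 1 to compound 2 (within the scatter) for a ring exchange, and no measured pair moves the methyl group on a thiophene. The expected change is no change at the digits printed from compound 2 to compound 3 (within the scatter) in this assay with nothing beyond the scatter anticipated. The estimate for compound 3 is 10000 nM with an expected range of 3000 nM to 20000 nM for the measurement.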

Compound 3, concentration for 50% growth inhibition: 50000 nM
Compound 3: middle estimate off by 5.0-fold (0.70 log units), on the low side; the measured number lies above the stated range.
By their numbers in this assay, from the lowest: compounds 1 and 2 (each within the scatter of the next); then compound 3.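

Moving the methyl group on the thiophene matters at this position: in this assay, 5-methylthiophen-2-yl in place of 3-methylthiophen-2-yl gives a 5.0-fold higher number from compound 2 to compound 3 (0.70 log units; beyond the scatter), a modest loss of growth inhibition with the same atoms joined differently. The earlier ring exchange showed no change, whereas 5-methylthiophen-2-yl in place of 2-fluorophenyl gives a 5.0-fold higher number from compound 1 to compound 3 (0.70 log units; beyond the scatter), so the group on this double-bonded chain carbon can shift the read-out. Nothing at hand accounts for the shift.

Still open, going by these compounds, is how a thiophene carrying chlorine or a methoxy group instead of the methyl would read, and whether an amine on this ring would lower the number.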